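Sulfonyl carbamate in place of benzoate on compound 1

This account rests on a few compounds, and the source may have more. Where it says the series, first, only, none or still open, it means among the compounds named here.

In a functional assay on MDA-MB-231 cells (Homo sapiens) for antiproliferative activity, read by MTT assay, with a stated time of 72 h (a lower number here means a stronger inhibitor, a higher number a weaker inhibitor), compound 1 `CC1=CC[C@H]2[C@H](CC[C@]2(C)O)C(C)(C)[C@@H]1CC[C@H]1[C@]2(C)CC[C@H](OC(=O)c3ccccc3)C(C)(C)O[C@H]2CC[C@@]1(C)O` gives 16100 nM, compound 2 `CC1=CC[C@H]2[C@@H]1CC=C(C)[C@@H](CC[C@H]1[C@]3(C)CC[C@H](OC(=O)c4ccc(Cl)cc4)C(C)(C)O[C@H]3CC[C@@]1(C)O)C2(C)C` gives 12700 nM and compound 3 `CC1=CC[C@H]2[C@H](CC[C@]2(C)O)C(C)(C)[C@@H]1CC[C@H]1[C@]2(C)CC[C@H](OCc3ccccc3)C(C)(C)O[C@H]2CC[C@@]1(C)O` gives 29100 nM. Compound 1 holds the middle of these three numbers, and its gaps to both others lie within the scatter.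

Compound 4 `CC1=CC[C@H]2[C@H](CC[C@]2(C)O)C(C)(C)[C@@H]1CC[C@H]1[C@]2(C)CC[C@H](OC(=O)NS(=O)(=O)c3ccc(C)cc3)C(C)(C)O[C@H]2CC[C@@]1(C)O` keeps the core of compound 1 and carries ((4-methylphenyl)sulfonyl)amino in place of phenyl on a carbonyl carbon.

Among the measured compounds shown here, one measured step bears on this change: benzyl in place of benzoyl on an oxygen on a saturated carbon gives a 1.8-fold higher number from compound 1 to compound 3 (0.26 log units; within the scatter). For the measured compounds named here, no measured compound carries the new group, so the evidence is indirect. The expected change in this assay is a 1.2-fold higher number from compound 1 to compound 4 (0.09 log units; within the scatter), no step beyond the scatter. Compound 4 is estimated at 20000 nM, with an expected range of 8000 nM to 50000 nM.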

Compound 4, half-maximal inhibitory concentration: 47100 nM
For compound 4 the middle estimate is 2.4-fold (0.37 log units) below the measured one; measured number inside the range.
By their numbers in this assay, from the lowest: compounds 2, 1, 3 and 4 (each within the scatter of the next, the first and the last beyond it).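

In this assay, among the compounds shown here, ((4-methylphenyl)sulfonyl)amino in place of phenyl on the carbonyl carbon gives a 2.9-fold higher number from compound 1 to compound 4 (0.47 log units; beyond the scatter), the first change at this position to pass the scatter and one towards a weaker inhibitor, whereas the earlier step gave a 1.8-fold higher number from compound 1 to compound 3 (0.26 log units; within the scatter). Nothing measured here accounts for this step.

Still open, on these data alone, is whether a plain amino group on the same carbonyl carbon, giving a simple carbamate, stays close to compound 1. Also open, as far as these compounds go, is whether methylsulfonylamino behaves like the larger group in compound 4.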